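Methyl-to-hydrogen step on a fused-ring nucleoside pair

The source may report more compounds than this note shows. Statements on the series, on what has been measured and on what is new or still open speak of the compounds shown alone.

Measured so far:
compound 1, `CSc1nc2cnsc2n1[C@@H]1O[C@H](CO)[C@@H](O)[C@@H]1O`: > 100000 nM
compound 2, `CSc1nc2c(C)nsc2n1[C@@H]1O[C@H](CO)[C@@H](O)[C@H]1O`: > 100000 nM

In a functional assay on L1210 cells (Mus musculus) for antiproliferative activity (on this read-out higher numbers stand for weaker inhibition and lower numbers for stronger inhibition), compound 2 gives only > 100000 nM, which is a limit of the assay and not a number. Compound 1 likewise gives > 100000 nM in this assay, again a limit. For the measured compounds named here, both values therefore sit at the limit of > 100000 nM in this assay, at which 2 of the 2 values shown sit, so no measured step between compounds is available and compound 2 cannot be placed relative to compound 1 beyond the shared limit.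

Compound 3, `CSc1nc2cnsc2n1[C@@H]1O[C@H](CO)[C@@H](O)[C@H]1O`, differs from compound 2 by hydrogen in place of methyl on an aromatic carbon, the change sitting on an aromatic carbon of the five-membered aromatic ring with one nitrogen and one sulfur in the fused system, next to the ring nitrogen.

With both measured values at the limit, the step from compound 2 to compound 3 is expected to be a step that the limit leaves unreadable from compound 2 to compound 3, that is, nothing beyond the scatter. Compound 3 is estimated at 150000 nM, within 50000 nM to 500000 nM, most likely reported again as a limit.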

Compound 3, half-maximal inhibitory concentration: > 100000 nM
Compound 3: only a limit was reported; the forecaster's own chance of this, stated with the estimate: 85%; the middle value lies beyond the limit too.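

In this assay compound 3 gives > 100000 nM as a limit and not a number. The steps to compound 3 from compound 2 and from compound 1 cannot be read: the limit of > 100000 nM in this assay, at which 3 of the 3 values shown sit. The compounds shown leave open whether the methyl group or the drawn configuration affects antiproliferative activity at all.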